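Replacing the amino alcohol side chain with an epoxide

The source may hold more compounds than are shown below. What is called first, only, known or untested is meant among the compounds shown, and "the series" means these compounds.

Of the compounds shown here, three sharing one core have been measured in a functional assay on HUVEC cells (Homo sapiens) for inhibition, read by MTT assay, with a stated time of 24 h, tested at 100 uM; on this read-out higher numbers stand for more inhibition of growth at the one concentration tested and lower numbers for less inhibition of growth. Compound 1 `COc1cc2ccc(=O)oc2cc1OCC(O)CN1CCN(C)CC1` gives 3.4%, compound 2 `COc1cc2ccc(=O)oc2cc1OCCCCBr` gives 16.9%, and compound 3 `COc1cc2ccc(=O)oc2cc1OCC(O)CNC(C)C` gives 6.3%. On these numbers compound 3 stands second highest of three; its gap to compound 1, a number 2.9 percentage points higher from compound 1 to compound 3 (within the scatter), is within the scatter, while the step of a number 10.6 percentage points lower from compound 2 to compound 3 (beyond the scatter) is beyond it. The next compound, compound 4 `COc1cc2ccc(=O)oc2cc1OCC1CO1`, differs from compound 3 by oxiran-2-yl in place of 1-hydroxy-2-(isopropylamino)ethyl on a saturated chain carbon bound to an oxygen on an aromatic ring. No measured step exchanges the same two groups, so the two steps shown give only indirect guidance: the swap of amines at the chain end moved the read-out within the scatter, and the change from the bromopropyl chain to the amino alcohol gave a modest loss. For compound 4 the step of a number 3.7 percentage points higher from compound 3 to compound 4 (within the scatter) in this assay is therefore expected to stay within the scatter. Compound 4 is estimated at 10%, with a range from 0% to 25%.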

Compound 4, percent growth inhibition at one concentration: 95.5%
Beside the measured number, compound 4's estimate is 85.5 percentage points below it; the measured number lies above the stated range.
By their numbers in this assay, from the lowest: compounds 1 and 3 (each within the scatter of the next); then compound 2; then compound 4.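

Among these compounds, at the saturated chain carbon bound to an oxygen on an aromatic ring, the earlier compounds had moved the read-out only slightly, but oxiran-2-yl in place of 1-hydroxy-2-(isopropylamino)ethyl brings a far larger change in this assay (a number 89.2 percentage points higher from compound 3 to compound 4 (beyond the scatter)). The high number does not follow simply from losing the amino alcohol, since compound 2, which also has no amine or hydroxyl group, still lies well under compound 4 (a number 78.6 percentage points higher from compound 2 to compound 4 (beyond the scatter)). Within this set, only the chain ending in the three-membered ring reaches such a number, and the data shown offer no explanation for the jump.

The compounds shown leave open whether the ring oxygen is required, which a cyclopropyl group or an oxetane ring at this place could test. They also leave open whether an open-chain 2,3-dihydroxypropyl group would keep any of this inhibition.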